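The source may hold more compounds than are shown below. What is called first, only, known or untested is meant among the compounds shown, and "the series" means these compounds.

Measured compounds:
Compound 1 (`CC1=CC[C@@H]([C@@](C)(O)CCCC(C)(C)NC=S)CC1`): 16000 nM in a functional assay on MCF7 cells (Homo sapiens) for cytotoxicity, read by sulforhodamine B assay; on this read-out higher numbers stand for weaker inhibition of growth and lower numbers for stronger inhibition of growth
Compound 2 (`CC1=CC[C@@H]([C@@](C)(O)CCCC(C)(C)NC(=S)N/N=C\c2ccc(C)cc2)CC1`): 7230 nM in this assay
Compound 3 (`COc1ccc(/C=N\NC(=S)NC(C)(C)CCC[C@](C)(O)[C@@H]2CC=C(C)CC2)cc1`): 6500 nM in this assay

Compound 2 stands second highest of the three numbers in this assay. Its nearest neighbour is compound 3, which gives 6500 nM; the two lie within the scatter of each other. Among the measured compounds shown here, compound 1, with 16000 nM, gives a higher number than compound 2, a gap beyond the scatter, though no single-point step connects these two compounds.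

Compound 4 (`CC1=CC[C@@H]([C@@](C)(O)CCCC(C)(C)NC(=S)N/N=C\c2ccc(O)cc2)CC1`) differs from compound 2 in one place: hydroxy in place of methyl on an aromatic carbon. For the measured compounds named here, the only measured step that bears on this change is the one at the same aromatic carbon, a 1.1-fold lower number from compound 2 to compound 3 (0.05 log units; within the scatter). That step swapped one small group for another at this position and moved the number by no more than the scatter. On that basis, a hydroxy group at the same carbon is expected to leave the number close to that of compound 2, with no step beyond the scatter in either direction in this assay. Compound 4 is therefore estimated at 6500 nM, in a range from 2700 nM to 15000 nM, which corresponds to an expected step of a 1.1-fold lower number from compound 2 to compound 4 (0.05 log units; within the scatter).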

Compound 4, concentration for 50% growth inhibition: 6230 nM
Compound 4: middle estimate off by 1.0-fold (0.02 log units), on the high side; the range from low to high includes it.
By their numbers in this assay, from the lowest: compounds 4, 3 and 2 (each within the scatter of the next); then compound 1.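

The earlier compounds shown here compared only methyl and methoxy on this aromatic carbon, para to a large group, whereas hydroxy, unlike methyl, counts as a hydrogen-bond donor and acceptor. In this assay the change from 4-methylphenyl to 4-hydroxyphenyl gives a 1.2-fold lower number from compound 2 to compound 4 (0.06 log units; within the scatter) and the replacement of methyl by hydrogen on the oxygen gives a 1.0-fold lower number from compound 3 to compound 4 (0.02 log units; within the scatter) in the same comparison series. Compounds 2, 3 and 4 therefore cannot be told apart in this read-out, so among these three the arrival of a hydrogen-bond donor and acceptor at this carbon leaves no step beyond the scatter, and the same holds for the loss of the methyl from the oxygen.

The compounds shown leave open whether an amine, a carboxylic acid or a chlorine atom on this carbon would also stay within the scatter of compound 2, and whether a hydroxy group would do so at another carbon of the ring. Nothing available here offers an explanation for how closely these three numbers agree.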